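Benzyl in Place of Hydrogen on Compound 2

The compounds below may be only part of what the source reports. "The series", "measured", "known", "first", "only" and "open" are said of these compounds alone.

Compound 1 `O=C(Nc1ccncc1)Nc1ccccc1F`: 100 mg/kg in a functional assay on the whole organism with Mus musculus as the target, in the maximal electroshock model, with a stated time of 30 min; on this read-out higher numbers stand for an effect only at larger amounts of compound and lower numbers for an effect already at smaller amounts
Compound 2 `O=C(Nc1ccncc1)Nc1ccccc1O`: > 300 mg/kg in this assay

In this assay compound 1 gives 100 mg/kg. In this assay compound 2 gives > 300 mg/kg, which is a limit of the assay and not a number. Compound 2 therefore stands at the limit of > 300 mg/kg in this assay, at which 1 of the 2 values shown sits, so its place among the numbers is known only as a range above that point. The one measured step, an at least 3.0-fold higher number from compound 1 to compound 2 (0.47 log units; beyond the scatter), runs from compound 1 to the limit, and its true size may be larger than shown.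

Compound 3 `O=C(Nc1ccncc1)Nc1ccccc1OCc1ccccc1` has not been measured in this assay. It differs from compound 2 in one place: benzyl in place of hydrogen on an oxygen on an aromatic ring. For the measured compounds named here, no measured step touches this kind of change; the only step on record, an at least 3.0-fold higher number from compound 1 to compound 2 (0.47 log units; beyond the scatter), concerns hydroxy in place of fluoro and says nothing about a benzyl entering on the oxygen. Starting from a limit, the direction is open. Compound 3 is expected to give about 200 mg/kg, within 50 mg/kg to 600 mg/kg, which means an expected step of an at least 1.5-fold lower number from compound 2 to compound 3 (0.17 log units; that floor lies within the scatter).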

Compound 3, minimum effective dose: > 300 mg/kg
Compound 3: a limit, no number; the forecaster's own chance of this, stated with the estimate: 45%; middle value at least 1.5-fold (0.17 log units) away from the limit.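

In this assay compound 3 gives > 300 mg/kg, which is a limit of the assay and not a number. Benzyloxy in place of the fluoro of compound 1 gives an at least 3.0-fold higher number from compound 1 to compound 3 (0.47 log units; beyond the scatter), so at this aromatic carbon a second group, after hydroxy, fails to reach the value that the fluoro compound gives. The step from compound 2 to compound 3 cannot be read, and whether benzyl on the oxygen changes anything stays unknown, with both compounds sitting at the same limit: the limit of > 300 mg/kg in this assay, at which 2 of the 3 values shown sit.

On these data alone, how far past that limit compound 2 and compound 3 really lie remains open, and so does the question of whether the two differ at all. Also open, as far as these compounds go, is whether methoxy or an amine on this aromatic carbon would give a number in this read-out, and how such a number would compare with that of compound 1.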